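This account rests on a few compounds, and the source may have more. Where it says the series, first, only, none or still open, it means among the compounds named here.

Measured in an assay on HEK293 cells for agonist activity at Toll-like receptor 8 (Homo sapiens), read by a luciferase reporter, with a stated time of 6 h; a lower number here means that less compound is needed, a higher number that more compound is needed for the effect:

Compound 1, `CCCCNc1nc(N)nc2c1CCN(Cc1ccccc1)C2`: 0.4 uM
Compound 2, `CCCCNc1nc(N)nc2c1CCN(C)C2`: 0.2 uM
Compound 3, `CCCCNc1nc(N)nc2c1CCN(C(C)=O)C2`: 0.4 uM

Compound 3 stands level with compound 1 at the digits shown, the two of them together the highest of the three numbers; the step of no change at the digits printed from compound 1 to compound 3 (within the scatter) and the step of a 2.0-fold higher number from compound 2 to compound 3 (0.30 log units; within the scatter) both stay within the scatter. Compound 4, `CCCCNc1nc(N)nc2c1CCN(C(=O)c1ccccc1)C2`, differs from compound 3 by phenyl in place of methyl on a carbonyl carbon. Among the compounds with values here, the only measured step that removes or adds a phenyl is a 2.0-fold lower number from compound 1 to compound 2 (0.30 log units; within the scatter), and the swap of groups on the ring nitrogen, a 2.0-fold higher number from compound 2 to compound 3 (0.30 log units; within the scatter), is likewise within the scatter. Within the data shown here, no step here has moved the number beyond the scatter, so for compound 4 the expected step is no change at the digits printed from compound 3 to compound 4 (within the scatter), no real change. The estimate for compound 4 is 0.4 uM, in a range from 0.15 uM to 1 uM.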

Compound 4, minimum effective concentration: 0.8 uM
Estimate against measurement, compound 4: 2.0-fold (0.30 log units) below, and the stated range covers the measured number.
By their numbers in this assay, from the lowest: compounds 2, 1, 3 and 4 (each within the scatter of the next, the first and the last beyond it).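

Phenyl in place of methyl on the carbonyl carbon gives a 2.0-fold higher number from compound 3 to compound 4 (0.30 log units; within the scatter), so this position accepts a phenyl ring without a real change. Benzoyl in place of benzyl on the amine nitrogen in the ring also gives a 2.0-fold higher number from compound 1 to compound 4 (0.30 log units; within the scatter), which leaves those two groups indistinguishable here. Within the data shown here, only the swap of methyl for benzoyl on that nitrogen gives a 4.0-fold higher number from compound 2 to compound 4 (0.60 log units; beyond the scatter), the first step beyond the scatter, though a modest one.

Nothing here explains why that step occurs. From the compounds shown here alone, it also remains open how an amine or a longer chain on the carbonyl carbon would compare with methyl and phenyl.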